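Solubility across a shared core: compound 3 to compound 4

This account rests on a few compounds, and the source may have more. Where it says the series, first, only, none or still open, it means among the compounds named here.

Measured compounds:
compound 1, `COc1ccc(F)cc1CNCCCNc1ccnc2cc(Cc3ccccc3)ccc12`, 4200 nM
compound 2, `COc1ccc(F)cc1CNCCCNc1ccnc2cc(-c3cccc4ccccc34)ccc12`, 32000 nM
compound 3, `COc1cccc(CNCCCNc2ccnc3cc(Cc4cccc(C(F)(F)F)c4)ccc23)c1O`, 4200 nM

In a physicochemical assay for solubility, with a stated time of 18 h, at pH 7.4 (a higher number here means a more soluble compound, a lower number a less soluble compound), compound 3 stands level with compound 1 at the digits given, and the two share the lowest numbers of the three. For the measured compounds named here, compound 2 sits furthest from compound 3, and the only step between measured compounds that differ in one place is a 7.6-fold higher number from compound 1 to compound 2 (0.88 log units; beyond the scatter), which concerns the group on the core rather than the group on the chain.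

Compound 4, `COc1ccc(F)cc1CNCCCNc1ccnc2cc(Cc3cccc(C(F)(F)F)c3)ccc12`, is not yet measured. It differs from compound 3 as follows: 5-fluoro-2-methoxyphenyl in place of 2-hydroxy-3-methoxyphenyl on a saturated chain carbon bound to an amine nitrogen. Going by the values given here, no measured pair shows this particular change, so nothing bears on it directly. Compound 1 carries the 5-fluoro-2-methoxyphenyl group and compound 3 the 2-hydroxy-3-methoxyphenyl group, and their values in this assay do not differ at the digits given, though other parts of those two structures also differ.

The step of a 1.2-fold lower number from compound 3 to compound 4 (0.08 log units; within the scatter) is therefore expected to lie within the scatter. Compound 4 is estimated at 3500 nM, with a range from 1000 nM to 12000 nM.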

Compound 4, solubility: 4200 nM
Estimate against measurement, compound 4: 1.2-fold (0.08 log units) below; the measured number falls inside the stated range.
By their numbers in this assay, from the lowest: compounds 1, 3 and 4 (each within the scatter of the next); then compound 2.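

In this assay, swapping 2-hydroxy-3-methoxyphenyl for 5-fluoro-2-methoxyphenyl on a saturated chain carbon bound to an amine nitrogen gives no change at the digits printed from compound 3 to compound 4 (within the scatter), although the two groups differ in their counts of hydrogen-bond donors and acceptors. Trifluoromethyl in place of hydrogen on an aromatic carbon likewise gives no change at the digits printed from compound 1 to compound 4 (within the scatter), whereas 3-(trifluoromethyl)benzyl in place of naphthalen-1-yl gives a 7.6-fold lower number from compound 2 to compound 4 (0.88 log units; beyond the scatter), so among these four compounds only the naphthalen-1-yl group of compound 2 stands apart. Nothing available explains either the flat steps or the larger one.

From the compounds shown here alone, whether a carboxylic acid or a further amine at the chain position would also leave the number unmoved remains open. So does the effect of a longer chain, and of a benzyl group carrying a nitrile on the shared core.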